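A few compounds are considered here, and "the series" means these few. Any claim that something is new, unique, unknown or untested is made for them only; others in the source may bear on it.

The compounds measured so far:

compound 1 `CC(c1ccc(Cl)cc1Cl)n1ncc2ncc(N3CCC(N4CCCCC4)CC3)nc21` — 2580 nM
compound 2 `Cc1nn(C(C)c2ccc(Cl)cc2Cl)c2nc(N3CCC(N4CCCCC4)C(C)C3)cnc12` — 126 nM
compound 3 `CC1CN(c2cnc3c(C#N)nn(C(C)c4ccc(Cl)cc4Cl)c3n2)CCC1N1CCCCC1` — 251 nM

In a functional assay on cells for antagonist activity at C-C chemokine receptor type 4 (Homo sapiens), read by fluorescence and calcium flux, with stated times of 2.5 s and 45 s (a lower number here means a stronger inhibitor, a higher number a weaker inhibitor), compound 3 gives 251 nM and stands second highest of the three numbers. Among the measured compounds shown here, its nearest neighbour is compound 2, which gives 126 nM in this assay; the only change between them is a 2.0-fold higher number from compound 2 to compound 3 (0.30 log units; within the scatter). For the measured compounds named here, compound 1 gives 2580 nM in this assay, but it differs from compound 3 in more than one place, so its value shows only that a compound lacking both the cyano group and the methyl on the piperidine ring sits well above the other two.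

Compound 4 `CC1CN(c2cnc3cnn(C(C)c4ccc(Cl)cc4Cl)c3n2)CCC1N1CCCCC1` has not been measured. It differs from compound 3 by hydrogen in place of cyano on an aromatic carbon. Going by the values given here, the one step that bears on this position is the one from methyl to cyano, which stayed within the scatter, so the substituent at this carbon seems to matter little; compound 1, however, leaves open that its high number owes something to the hydrogen there. Compound 4 is therefore expected at 600 nM, with a range from 150 nM to 2500 nM. This estimate means a step of a 2.4-fold higher number from compound 3 to compound 4 (0.38 log units; beyond the scatter), and it is expected to stay close to compound 3 while allowing for the weaker end that compound 1 shows.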

Compound 4, half-maximal inhibitory concentration: 238 nM
Estimate against measurement, compound 4: 2.5-fold (0.40 log units) above; measured number inside the range.
By their numbers in this assay, from the lowest: compounds 2, 4 and 3 (each within the scatter of the next); then compound 1.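

In this assay, the nitrile can give way to hydrogen with no reading beyond the scatter (a 1.1-fold lower number from compound 3 to compound 4 (0.02 log units; within the scatter)), and the same holds when hydrogen replaces methyl (a 1.9-fold higher number from compound 2 to compound 4 (0.28 log units; within the scatter)). Hydrogen, methyl and cyano on this aromatic carbon, two ring bonds from the ring atom that bears a 1-(2,4-dichlorophenyl)ethyl group, therefore cannot be told apart here. Compound 1 and compound 4 both carry hydrogen at that carbon. Methyl in place of hydrogen on a saturated ring carbon gives a large step (an 11-fold lower number from compound 1 to compound 4 (1.04 log units; beyond the scatter)).

Going by these compounds, whether an amine, a carboxylic acid or a longer chain on the aromatic carbon would also leave the number within the scatter remains open. No measurement is available that explains either the flat reading at the aromatic carbon or the large step at the saturated ring carbon.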